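Methyl for Amino on a Urea Kinase Inhibitor Core

This account rests on a few compounds, and the source may have more. Where it says the series, first, only, none or still open, it means among the compounds named here.

Compound 1 `Nc1cc(Oc2ccc(NC(=O)Nc3cccc(C(F)(F)F)c3)cc2)ncn1`: 25 nM
Compound 2 `CNc1cc(Oc2ccc(NC(=O)Nc3cccc(C(C)(F)F)c3)cc2)ncn1`: 40 nM
Compound 3 `CNc1cc(Oc2ccc(NC(=O)Nc3cccc(C(C)(C)C)c3)cc2)ncn1`: 40 nM

Of the compounds shown here, three sharing a diaryl urea core have been measured in an assay on isolated protein for inhibition of serine/threonine-protein kinase TNNI3K (Homo sapiens); a lower number here means a stronger inhibitor, a higher number a weaker inhibitor. Compound 1 gives 25 nM, the lowest of the three numbers, but compound 2 at 40 nM and compound 3 at 40 nM both lie within the scatter of it, so no order among the three can be claimed. Going by the values given here, the single one-place step recorded, no change at the digits printed from compound 2 to compound 3 (within the scatter), concerns the aryl group on the far side of the urea. Compounds 1 and 2 differ in two places at once, so their values show only that the two sit close together.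

Compound 4 `Cc1cc(Oc2ccc(NC(=O)Nc3cccc(C(F)(F)F)c3)cc2)ncn1` has not yet been measured. It differs from compound 1 in one place: methyl in place of amino on an aromatic carbon. Among the compounds with values here, no measured step touches this part of the core; the one step available, on the other aryl ring, brought no change beyond the scatter and offers no guide for a change on the core itself. Within the data shown here, with no matching precedent, compound 4 is expected to give 60 nM, within a range from 15 nM to 250 nM. This estimate means an expected step of a 2.4-fold higher number from compound 1 to compound 4 (0.38 log units; beyond the scatter), a modest weakening that could just as well turn out to be no change at all.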

Compound 4, half-maximal inhibitory concentration: 160 nM
For compound 4 the middle estimate is 2.7-fold (0.43 log units) below the measured one, within the range that was stated.
By their numbers in this assay, from the lowest: compounds 1, 2 and 3 (each within the scatter of the next); then compound 4.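

Where the only earlier one-place step, no change at the digits printed from compound 2 to compound 3 (within the scatter), concerned the aryl group at the other end of the urea, this change on the core gives the first step beyond the scatter in this assay: a 6.4-fold higher number from compound 1 to compound 4 (0.81 log units; beyond the scatter). It shows that the 6-aminopyrimidin-4-yl group of compound 1 cannot be exchanged for 6-methylpyrimidin-4-yl without a loss in this assay, even though the heavy-atom count stays the same and only the counted hydrogen-bond donor and acceptor of the amino group are gone. Nothing measured here explains the step or ties it to those counts.

The compounds shown leave open how a hydroxyl, a methoxy or a dimethylamino group would read on this same aromatic carbon, which would show whether the amino group itself matters or only the presence of something other than methyl. A methylamino group paired with the trifluoromethyl group of compound 1 would also separate the two differences that now stand together between compound 1 and compound 2.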